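Phenyl in Place of Furan on the Amide Carbonyl

This account rests on a few compounds, and the source may have more. Where it says the series, first, only, none or still open, it means among the compounds named here.

The compounds share one core: an aromatic ring bearing an amide, joined through a carbonyl and a double bond to a second aromatic ring. Compound 1 `O=C(/C=C/c1ccco1)c1ccc(NC(=O)c2ccccc2)cc1` carries a benzamido group and a furan at the far end. In a toxicity assay on FHC cells (Homo sapiens) for cytotoxicity, read by resazurin assay, with a stated time of 48 h (a higher number here means that more compound is tolerated, a lower number that less compound is tolerated), compound 1 is reported only as a limit of the measurement, > 100000 nM. Compound 2 `CC(=O)Nc1ccc(C(=O)/C=C/c2cccc([N+](=O)[O-])c2)cc1` has a nitro-bearing ring at the far end and a small acetyl group on the amide nitrogen; in this assay compound 2 gives 15000 nM. Compound 3 `O=C(/C=C/c1cccc([N+](=O)[O-])c1)c1ccc(NC(=O)c2ccco2)cc1` keeps the nitro ring but has furan-2-yl in place of methyl. In this assay compound 3 is again reported only as a limit, > 100000 nM. From the compounds shown here alone, the step of an at least 6.6-fold higher number from compound 2 to compound 3 (0.82 log units; beyond the scatter) is bounded by the limit of > 100000 nM in this assay, at which 2 of the 3 values shown sit, so its true size is unknown.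

Compound 4 `O=C(/C=C/c1cccc([N+](=O)[O-])c1)c1ccc(NC(=O)c2ccccc2)cc1` differs from compound 3 by phenyl in place of furan-2-yl on a carbonyl carbon. Within the data shown here, only that one measured step bears on this change, and compound 1 shows a benzamido group on this core also reaching the boundary. The step of a number no higher from compound 3 to compound 4 (the limit leaves the size open) is therefore expected to stay within the scatter. Compound 4 is estimated at 100000 nM, with a range from 30000 nM to 300000 nM, most likely reported again only as a limit.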

Compound 4, half-maximal cytotoxic concentration: > 100000 nM
Compound 4: no number, only a limit; the forecaster's own chance of this, stated with the estimate: 70%; the middle value sits exactly at the limit.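

In this assay compound 4 gives > 100000 nM as a limit of the measurement, so phenyl on the amide carbonyl ends at the same limit as furan-2-yl on this nitro-bearing core. In this assay the change from methyl to phenyl on that carbonyl gives an at least 6.6-fold higher number from compound 2 to compound 4 (0.82 log units; beyond the scatter) and so goes the same way as the change to furan-2-yl, which means the higher number is not tied to furan-2-yl alone. From the compounds shown here alone, the steps to compound 4 from compound 3 and from compound 1 cannot be read, and the true size of the rise from methyl stays unknown: the limit of > 100000 nM in this assay, at which 3 of the 4 values shown sit.

Going by these compounds, whether phenyl and furan-2-yl differ at all remains open. Also open, on these data alone, is how a longer chain in place of methyl, or a phenyl carrying an amine or a carboxylic acid, would stand in this assay on this core.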